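A few compounds are considered here, and "the series" means these few. Any claim that something is new, unique, unknown or untested is made for them only; others in the source may bear on it.

Compound 1 `COc1cc(C(=O)c2cn(-c3ccccc3C)cc2-c2ccccc2)cc(OC)c1OC` and compound 2 `COc1cc(C(=O)c2cn(-c3ccccc3Cl)cc2-c2ccccc2)cc(OC)c1OC` share one core and differ only in the group carried on the aromatic nitrogen. In a functional assay on MCF7 cells (Homo sapiens) for cytotoxicity, read by MTT assay, with a stated time of 96 h (a lower number here means a stronger inhibitor, a higher number a weaker inhibitor), compound 1 gives 2200 nM, and compound 2 gives 1800 nM. Within the data shown here, the step of a 1.2-fold lower number from compound 1 to compound 2 (0.09 log units; within the scatter) is the only measured comparison available. Among the two numbers compound 2 holds the lower one, but the gap to compound 1 lies within the scatter, so neither compound can be called the stronger of the pair. Compound 3 `COc1cc(C(=O)c2cn(-c3ccc(Cl)cc3)cc2-c2ccccc2)cc(OC)c1OC` has not yet been measured in this assay. It differs from compound 2 as follows: 4-chlorophenyl in place of 2-chlorophenyl on an aromatic nitrogen. Among the measured compounds shown here, the single measured step concerns a different kind of change, the exchange of one group for another, and no measured pair shows what moving the chlorine from a 2-chlorophenyl to a 4-chlorophenyl does. For the measured compounds named here, there is thus no measured step that bears directly on this change. The expected step is a 1.2-fold lower number from compound 2 to compound 3 (0.08 log units; within the scatter), with no confident direction and a wide range. Compound 3 is expected to give about 1500 nM in this assay, between 500 nM and 5000 nM.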

Compound 3, half-maximal inhibitory concentration: 140 nM
Compound 3: middle estimate off by 11-fold (1.03 log units), on the high side; measured number outside the range, below it.
By their numbers in this assay, from the lowest: compound 3; then compounds 2 and 1 (each within the scatter of the next).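

In this assay, the earlier pair showed almost no response at the group on the aromatic nitrogen, since chloro in place of methyl gave only a 1.2-fold lower number from compound 1 to compound 2 (0.09 log units; within the scatter); compound 3 shows that this position is nonetheless highly sensitive, as 4-chlorophenyl in place of 2-chlorophenyl gives a 13-fold lower number from compound 2 to compound 3 (1.11 log units; beyond the scatter). The two groups have the same atoms, so the arrangement of the chlorine on this phenyl ring alone separates compound 2 from compound 3, and 4-chlorophenyl in place of 2-methylphenyl likewise gives a 16-fold lower number from compound 1 to compound 3 (1.20 log units; beyond the scatter), which makes compound 3 the strongest of the three in this assay. The data at hand offer no explanation for this large difference.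

The compounds shown leave open whether the gain depends on chlorine itself, as 4-methylphenyl or 4-methoxyphenyl on the same nitrogen could either match compound 3 or stay close to compounds 1 and 2. They also leave open whether the same step would appear if the phenyl group on the shared core gave way to another group, such as a 4-methoxyphenyl group.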